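Side-chain swap on a macrocyclic core: carboxy to methyl

The compounds below may be only part of what the source reports. "The series", "measured", "known", "first", "only" and "open" are said of these compounds alone.

Measured so far in a functional assay on P388 cells (Mus musculus) for cytotoxicity; a lower number here means a stronger inhibitor, a higher number a weaker inhibitor:
- compound 1 `COc1ccc(C[C@H]2C(=O)N[C@@H](C)C(=O)N(C)[C@H]3Cc4ccc(cc4)Oc4cc(ccc4OC)C[C@@H](C(=O)N[C@H](C)C(=O)N[C@@H](CCC(=O)O)C(=O)N2C)N(C)C3=O)cc1` gives 219 nM
- compound 2 `COc1ccc(C[C@H]2C(=O)N[C@@H](C)C(=O)N(C)[C@H]3Cc4ccc(cc4)Oc4cc(ccc4OC)C[C@@H](C(=O)N[C@H](C)C(=O)N[C@@H](CS)C(=O)N2C)N(C)C3=O)cc1` gives 363 nM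
- compound 3 `COc1ccc(C[C@H]2C(=O)N[C@@H](C)C(=O)N(C)[C@H]3Cc4ccc(cc4)Oc4cc(ccc4OC)C[C@@H](C(=O)N[C@H](C)C(=O)N[C@@H](CCCO)C(=O)N2C)N(C)C3=O)cc1` gives 174 nM

Compound 1 sits second highest of the three numbers; its nearest neighbour is compound 3 and the gap to it is within the scatter, as is the gap to compound 2. The unmeasured compound 4 `CCC[C@@H]1NC(=O)[C@@H](C)NC(=O)[C@@H]2Cc3ccc(OC)c(c3)Oc3ccc(cc3)C[C@@H](C(=O)N2C)N(C)C(=O)[C@H](C)NC(=O)[C@H](Cc2ccc(OC)cc2)N(C)C1=O` differs from compound 1 at one side chain: methyl in place of carboxy on a saturated chain carbon, two bonds along the chain from a saturated ring carbon

Going by the values given here, two measured steps bear on this. The closest is a 1.3-fold lower number from compound 1 to compound 3 (0.10 log units; within the scatter), in which the carboxy is also replaced at the same place, by hydroxymethyl. The other is a 1.7-fold higher number from compound 1 to compound 2 (0.22 log units; within the scatter), a change at the neighbouring chain carbon. Among the compounds with values here, both stay within the scatter, and the only step beyond it, a 2.1-fold lower number from compound 2 to compound 3 (0.32 log units; beyond the scatter), is modest. Replacing carboxy by methyl is therefore expected to move the number in this assay little, with no step beyond the scatter in either direction; the expected step is a 1.0-fold lower number from compound 1 to compound 4 (0.02 log units; within the scatter). Compound 4 is thus estimated at 210 nM, with a range from 80 nM to 550 nM.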

Compound 4, half-maximal inhibitory concentration: 13.8 nM
Compound 4: middle estimate off by 15-fold (1.18 log units), on the high side; the measured number lies below the stated range.
By their numbers in this assay, from the lowest: compound 4; then compounds 3, 1 and 2 (each within the scatter of the next, the first and the last beyond it).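

In this assay this side chain is far from indifferent: the propyl chain of compound 4 stands clearly apart from the carboxy end of compound 1 (a 16-fold lower number from compound 1 to compound 4 (1.20 log units; beyond the scatter)), the hydroxy end of compound 3 (a 13-fold lower number from compound 3 to compound 4 (1.10 log units; beyond the scatter)) and the sulfanyl group of compound 2 (a 26-fold lower number from compound 2 to compound 4 (1.42 log units; beyond the scatter)). Compounds 1 and 3 lie within the scatter of each other, so the large step appears only with the chain end that carries neither carboxy nor hydroxy, and not on exchanging one of these groups for the other. Nothing available here accounts for the size of this step.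

On these data alone, whether a butyl or a branched chain matches the propyl chain remains open. So does whether a terminal amine or methoxy group on the same chain falls with compounds 1 and 3 or nearer compound 4.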